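The source may hold more compounds than are shown below. What is called first, only, known or untested is meant among the compounds shown, and "the series" means these compounds.

Within the data shown here, compound 2 `Cc1oncc1-c1cccc2c1CCC2c1ncc[nH]1` stands with the larger of the two values in a functional assay on CHO cells for agonist activity at Alpha-1A adrenergic receptor (Homo sapiens), read by FLIPR and calcium flux (a lower number here means a smaller maximal response, a higher number a larger maximal response), giving 63%; its only neighbour, compound 1 `Cn1nccc1-c1cccc2c1CCC2c1ncc[nH]1`, gives 58% in this assay, and the two lie within the scatter of one another. Among the measured compounds shown here, the one measured step, a number 5 percentage points higher from compound 1 to compound 2 (within the scatter), exchanges one five-membered aromatic ring for another on the same aromatic carbon and moves the response by no more than the scatter. Compound 3 `CNC(=O)c1cccc2c1CCC2c1ncc[nH]1` carries a different kind of change: methylcarbamoyl in place of 5-methyl-1,2-oxazol-4-yl on an aromatic carbon. For the measured compounds named here, no measured step exchanges a ring for an open-chain group here, so the step from compound 1 to compound 2 bears on the step to compound 3 only loosely, showing that this position tolerates a swap of ring without a change beyond the scatter. Compound 3 is therefore expected to give roughly 55% in this assay, between 35% and 75%, a step of a number 8 percentage points lower from compound 2 to compound 3 (within the scatter) that is estimated to stay within the scatter.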

Compound 3, largest response reached (Emax), in percent of the reference or control that the assay uses: 59%
The estimate for compound 3 lay 4 percentage points below the measured number; low and high end bracket the measured number.
By their numbers in this assay, from the lowest: compounds 1, 3 and 2 (each within the scatter of the next).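

In this assay, the position tolerates more than an exchange of one five-membered aromatic ring for another: the open-chain methylcarbamoyl group gives a number 4 percentage points lower from compound 2 to compound 3 (within the scatter), and, measured against the other ring, a number 1 percentage points higher from compound 1 to compound 3 (within the scatter). Across these three compounds, therefore, neither a ring on this aromatic carbon nor the absence of a hydrogen-bond donor is needed to keep the maximal response within the scatter. Nothing available here explains why these three groups behave alike.

As far as these compounds go, whether an amine, a carboxylic acid or a longer alkyl chain on this carbon would move the response beyond the scatter remains open. So does the part played by the amide hydrogen, which a dimethylcarbamoyl group in the same place would test.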